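A few compounds are considered here, and "the series" means these few. Any claim that something is new, unique, unknown or untested is made for them only; others in the source may bear on it.

Values in a functional assay with Oryctolagus cuniculus as the target; a lower number here means a stronger inhibitor, a higher number a weaker inhibitor:
- compound 1 `COc1ccc(-c2nc(N=C(N)N)sc2-c2ccc(OC)cc2)cc1`: 31000 nM
- compound 2 `CC/N=C(/N)Nc1nc(-c2ccc(OC)cc2)c(-c2ccc(OC)cc2)s1`: > 100 nM, a limit
- compound 3 `COc1ccc(-c2nc(/N=C(\N)[N+]3(C)CCCCC3)sc2-c2ccc(OC)cc2)cc1`: > 1000 nM, a limit

Compound 3 has no number on this assay, only the limit > 1000 nM.

The change to compound 4 `COc1ccc(-c2nc(CNC(C)=O)sc2-c2ccc(OC)cc2)cc1` is a group of 5 heavy atoms (3 carbon, 1 nitrogen, 1 oxygen; no ring) in place of a group of 10 heavy atoms (7 carbon, 3 nitrogen; one six-membered non-aromatic ring with 1 hetero atom), on an aromatic carbon. Acetamidomethyl enters with no net charge, on the same aromatic carbon.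

The steps a step that the limit leaves unreadable from compound 1 to compound 3 and a step that the two limits leave unreadable from compound 2 to compound 3 bear on this change, as does a step that the limit leaves unreadable from compound 1 to compound 2, but the size of none can be read. For the measured compounds named here, the only number is compound 1 at 31000 nM, so a value of that general order is expected, with a weak inhibitor the likelier outcome.

The expected step is a step that the limit leaves unreadable from compound 3 to compound 4, and its direction remains uncertain.

For compound 4 the estimate is 10000 nM, with an expected range of 800 nM to 100000 nM.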

Compound 4, half-maximal inhibitory concentration: 15 nM
Beside the measured number, compound 4's estimate is 670-fold (2.82 log units) above it; measured number outside the range, below it.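

In this assay, acetamidomethyl, with no net charge, on this aromatic carbon makes compound 4 the most potent of the four, with a 2100-fold lower number from compound 1 to compound 4 (3.32 log units; beyond the scatter). The limits on compounds 2 and 3 fix only minimum sizes for the other two gaps, with an at least 66-fold lower number from compound 3 to compound 4 (1.82 log units; beyond the scatter) and an at least 6.6-fold lower number from compound 2 to compound 4 (0.82 log units; beyond the scatter). Nothing measured here accounts for the gain.

The steps among compounds 1, 2 and 3 cannot be read, so those groups stay unranked against each other. On these data alone, whether a free aminomethyl amine, a carboxylic acid or a longer acyl chain on this carbon would hold the potency of compound 4 remains open.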